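This account rests on a few compounds, and the source may have more. Where it says the series, first, only, none or still open, it means among the compounds named here.

Measured compounds:
compound 1, `CC1(c2ccc(-c3ccc4ccccc4c3)[nH]c2=O)OC(=O)NC1=O`, gives 20 nM in a functional assay on CHO cells for antagonist activity at prostaglandin E2 receptor EP3 subtype (Homo sapiens), read by FLIPR, with a stated time of 1 h; on this read-out lower numbers stand for stronger inhibition and higher numbers for weaker inhibition
compound 2, `O=C1NC(=O)C(c2ccc(-c3ccc4ccccc4c3)[nH]c2=O)(C2CCOCC2)O1`, gives 200 nM in this assay

Among the compounds with values here, on these two numbers compound 1 stands lowest, and the only other compound, compound 2, lies away by a 10-fold higher number from compound 1 to compound 2 (1.00 log units; beyond the scatter), a step that puts oxan-4-yl in place of methyl on a saturated ring carbon. The unmeasured compound 3, `Cn1c(-c2ccc3ccccc3c2)ccc(C2(C)OC(=O)NC2=O)c1=O`, is reached from compound 1 by a different change: methyl in place of hydrogen on an aromatic nitrogen. Within the data shown here, the one measured step does not touch this aromatic nitrogen, so nothing measured here bears directly on the change from compound 1 to compound 3; the data only show that the shared core tolerates a small group at the saturated ring carbon far better than a large one. Among the measured compounds shown here, with no step at the aromatic nitrogen to rest on, the expectation for compound 3 is worded cautiously: a step of a 3.0-fold higher number from compound 1 to compound 3 (0.48 log units; beyond the scatter) is expected in this assay, most likely a modest weakening, though a result within the scatter of compound 1 cannot be ruled out. Compound 3 is therefore estimated at 60 nM, with a range from 15 nM to 300 nM.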

Compound 3, inhibition constant: > 25100 nM
Compound 3 was reported as a limit; the forecaster's own chance of this, stated with the estimate: 5%; middle value at least 410-fold (2.62 log units) away from the limit.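

In this assay compound 3 gives > 25100 nM, which is a limit of the assay and not a number. The step at the aromatic nitrogen, an at least 1200-fold higher number from compound 1 to compound 3 (3.09 log units; beyond the scatter), is therefore a bound, and it goes well past the step at the saturated ring carbon, a 10-fold higher number from compound 1 to compound 2 (1.00 log units; beyond the scatter), even though only methyl enters in place of hydrogen, a single heavy atom. This shows for the first time that this aromatic nitrogen is far less forgiving of change than the saturated ring carbon, although the full size of the loss remains unknown, as the only record for compound 3 is a limit: the limit of > 25100 nM in this assay, at which 1 of the 3 values shown sits.

The compounds shown cannot tell whether the loss follows from losing the hydrogen on this nitrogen or from the methyl that enters there, and they give no cause for it. Nor do they show how an ethyl group, a longer chain ending in an amine or a carboxylic acid, or a different replacement for the hydrogen at this nitrogen would read out on this same core.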